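A few compounds are considered here, and "the series" means these few. Any claim that something is new, unique, unknown or untested is made for them only; others in the source may bear on it.

Compound 1 `C=Cc1ccc(S(=O)(=O)Nc2ccc3oc(-c4ccccc4)nc3c2)cc1` and compound 2 `C=Cc1ccc(S(=O)(=O)Nc2ccc(-c3nc4ccccc4o3)cc2)cc1` share the same atoms joined in different ways; the difference between the two cores is not broken down here. In an ADME assay on HEK293 cells (Homo sapiens) for cytotoxicity, read by resazurin assay, with a stated time of 48 h (a higher number here means that more compound is tolerated, a lower number that less compound is tolerated), compound 1 gives 53000 nM. For compound 2 this assay reports only a limit, > 100000 nM. Compound 3 `O=S(=O)(Nc1ccc2oc(-c3ccccc3)nc2c1)c1ccc(O)cc1` carries a hydroxy in place of vinyl on an aromatic carbon relative to compound 1 (hydroxy in place of vinyl on an aromatic carbon). For compound 3 this assay again reports only a limit, > 100000 nM. The measured step of an at least 1.8-fold higher number from compound 1 to compound 3 (0.27 log units; that floor lies within the scatter) is therefore bounded by the limit of > 100000 nM in this assay, at which 2 of the 3 values shown sit, rather than by a number. Compound 4 `O=S(=O)(Nc1ccc(-c2nc3ccccc3o2)cc1)c1ccc(O)cc1` stands to compound 2 as compound 3 stands to compound 1, the same change at the same kind of position (hydroxy in place of vinyl on an aromatic carbon). Given the step of an at least 1.8-fold higher number from compound 1 to compound 3 (0.27 log units; that floor lies within the scatter), compound 4 is expected to remain at or beyond the same limit in this assay, with an estimate of 130000 nM and a range from 60000 nM to 300000 nM. The step expected from compound 2 to compound 4 is thus a step that the limit leaves unreadable from compound 2 to compound 4, which for a pair already sitting at a limit means no measurable change.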

Compound 4, half-maximal cytotoxic concentration: > 100000 nM
Compound 4 gave a limit, no number; the forecaster's own chance of this, stated with the estimate: 85%; the middle value does not contradict the limit.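

No step can be read from compound 2 to compound 4 in this assay, since both compounds give a limit and neither gives a number: the limit of > 100000 nM in this assay, at which 3 of the 4 values shown sit.

The compounds shown leave open how far compound 2, compound 3 and compound 4 lie beyond that limit, and so whether 4-vinylphenyl to 4-hydroxyphenyl changes the tolerated concentration equally on both cores.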